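One Methoxy Substitution, Two Pairs of Compounds

The source may hold more compounds than are shown below. What is called first, only, known or untested is meant among the compounds shown, and "the series" means these compounds.

The measured compounds:
- compound 1, `O=S(=O)(c1ccc2ccccc2c1)N(CCCN1CCN(c2ccccc2)CC1)CC1CCCCC1`, which in an assay on CHO cells for displacement of a labelled ligand from 5-hydroxytryptamine receptor 7 (Homo sapiens) (a higher number here means a weaker inhibitor, a lower number a stronger inhibitor), gives 1240 nM
- compound 2, `COc1ccccc1N1CCN(CCCN(CC2CCCCC2)S(=O)(=O)c2ccc3ccccc3c2)CC1`, which in this assay gives 500 nM
- compound 3, `CC(CCN1CCN(c2ccccc2)CC1)NS(=O)(=O)c1ccc2ccccc2c1`, which in this assay gives 657 nM

Compound 1 and compound 2 differ in one place only: methoxy in place of hydrogen on an aromatic carbon. That change produced a 2.5-fold lower number from compound 1 to compound 2 (0.39 log units; beyond the scatter).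

Compound 3 carries a different core from compound 1; the difference between the two cores is not broken down here. Compound 3 and compound 2 give values within the scatter of each other, and so do compound 3 and compound 1, so nothing can be said about their order.

Compound 4, `COc1ccccc1N1CCN(CCC(C)NS(=O)(=O)c2ccc3ccccc3c2)CC1`, has not yet been measured. It differs from compound 3 in exactly the way compound 2 differs from compound 1: methoxy in place of hydrogen on an aromatic carbon. The place is described in the same words in both pairs, so this is the same change made on a different core.

The expectation for compound 4 rests on a single precedent: the step of a 2.5-fold lower number from compound 1 to compound 2 (0.39 log units; beyond the scatter). Carried over to the core of compound 3, compound 4 is expected to show a 2.3-fold lower number from compound 3 to compound 4 (0.37 log units; beyond the scatter) in this assay. Among the compounds with values here, only one earlier instance of this change exists, and it stands on another core. The range is therefore kept wide. The estimate for compound 4 in this assay is 280 nM, with a range from 120 nM to 650 nM.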

Compound 4, half-maximal inhibitory concentration: 316 nM
Compound 4: the middle estimate sits 1.1-fold (0.05 log units) below what was measured; the measured number falls inside the stated range.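

On the core of compound 3, the change from phenyl to 2-methoxyphenyl gave, in this assay, a 2.1-fold lower number from compound 3 to compound 4 (0.32 log units; beyond the scatter). Set beside the step on the core of compound 1, the new step points the same way and cannot be told apart from it in size: the same change on two cores in this assay, a 2.5-fold lower number (0.39 log units; beyond the scatter) from compound 1 to compound 2 and a 2.1-fold lower number (0.32 log units; beyond the scatter) from compound 3 to compound 4, 1.2-fold (0.08 log units) apart, within the scatter of two such steps. In this series, then, the methoxy change carried from one core to the other with its direction and size intact within the scatter, but that rests on two cores and a single assay, so it shows neither that the step would hold on a further core nor why the number falls at all.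

The compounds shown leave open whether another group on the same aromatic carbon, such as ethoxy, a chlorine atom or a hydroxyl, would lower the number in the same way, and whether methoxy on a different carbon of that ring would do so. They also leave open whether the step survives on a core with a longer chain between the sulfonamide nitrogen and the piperazine, and how the change reads on any receptor other than the one tested here.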